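The source may report more compounds than this note shows. Statements on the series, on what has been measured and on what is new or still open speak of the compounds shown alone.

Compound 1 `CCCCCCNc1nc(SCc2ccc(C(F)(F)F)cc2)nc2ccccc12` is the hexyl member of the series. In a functional assay on PC-3 cells (Homo sapiens) for cytotoxicity, read by MTT assay, with a stated time of 72 h (a lower number here means a stronger inhibitor, a higher number a weaker inhibitor), compound 1 gives 19000 nM, the highest of the three numbers in hand. Its nearest neighbour is compound 2 `FC(F)(F)c1ccc(CSc2nc(Nc3cccc(C(F)(F)F)c3)c3ccccc3n2)cc1`, which in this assay gives 12900 nM; the furthest is compound 3 `FC(F)(F)c1ccc(CSc2nc(Nc3cccc(Br)c3)c3ccccc3n2)cc1`, which in this assay gives 8680 nM. The two aryl replacements of the hexyl chain read a 1.5-fold lower number from compound 1 to compound 2 (0.17 log units; within the scatter) and a 2.2-fold lower number from compound 1 to compound 3 (0.34 log units; beyond the scatter); between the two aryl members, the swap of bromo for trifluoromethyl reads a 1.5-fold lower number from compound 2 to compound 3 (0.17 log units; within the scatter).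

Compound 4 `O=[N+]([O-])c1cccc(Nc2nc(SCc3ccc(C(F)(F)F)cc3)nc3ccccc23)c1` carries a third aryl group in the same place. Compared with compound 1 the change is 3-nitrophenyl in place of hexyl on a nitrogen on an aromatic ring. Within the data shown here, the steps that bear on it are the two other aryl-for-hexyl steps, both small and both toward lower numbers, one within the scatter and one just beyond it. Nothing in hand separates a 3-nitrophenyl from the other two aryl groups, so no larger or differently directed effect can be read from the series. The expected step is therefore a 1.7-fold lower number from compound 1 to compound 4 (0.24 log units; within the scatter). A result within the scatter would be no surprise. Compound 4 is expected to give 11000 nM in this assay, with a range from 5000 nM to 25000 nM.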

Compound 4, half-maximal inhibitory concentration: 13500 nM
For compound 4 the middle estimate is 1.2-fold (0.09 log units) below the measured one; the measured number falls inside the stated range.
By their numbers in this assay, from the lowest: compounds 3, 2, 4 and 1 (each within the scatter of the next, the first and the last beyond it).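

In this assay the replacement of hexyl by 3-nitrophenyl reads a 1.4-fold lower number from compound 1 to compound 4 (0.15 log units; within the scatter) and so stays inside the scatter, which leaves 3-bromophenyl as the only one of the three aryl groups with a step from hexyl beyond it. Among these compounds, the new compound also gives the first comparison of nitro with the other two substituents on the aromatic carbon, and it separates from neither: nitro in place of bromo reads a 1.6-fold higher number from compound 3 to compound 4 (0.19 log units; within the scatter) and nitro in place of trifluoromethyl reads a 1.0-fold higher number from compound 2 to compound 4 (0.02 log units; within the scatter), so compounds 2, 3 and 4 all lie within the scatter of one another despite carrying three different substituents. No measurement in hand accounts for this flat reading across the aryl members.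

Still open, as far as these compounds go, is whether an unsubstituted phenyl, or a phenyl carrying a carboxylic acid or a primary amine, would give a step beyond the scatter from these aryl members. Also open, from the compounds shown here alone, is whether a shorter alkyl chain or a longer one in place of hexyl would read differently from compound 1 in this assay, where every number so far sits in one narrow band.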